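A few compounds are considered here, and "the series" means these few. Any claim that something is new, unique, unknown or untested is made for them only; others in the source may bear on it.

In a functional assay on HCT-15 cells (Homo sapiens) for inhibition (a lower number here means a stronger inhibitor, a higher number a weaker inhibitor), two close relatives of compound 3 have already been tested. Compound 1 `Oc1ccccc1-c1cc(-c2cccc(F)c2)cc(-c2ccccc2O)n1` gives > 50000 nM, which is a limit of the assay rather than a number. Compound 2 `Oc1ccccc1-c1cc(-c2cccc(C(F)(F)F)c2)cc(-c2ccccc2O)n1` likewise gives > 50000 nM, again a limit rather than a measured value. The step that the two limits leave unreadable from compound 1 to compound 2 therefore cannot be read, since (the limit of > 50000 nM in this assay, at which 2 of the 2 values shown sit). Going by the values given here, compound 2 thus stands at that limit, and so does the one other value shown.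

Compound 3 `Oc1ccccc1-c1cc(-c2cccc(OC(F)(F)F)c2)cc(-c2ccccc2O)n1` differs from compound 2 in a single place: trifluoromethoxy in place of trifluoromethyl on an aromatic carbon. Among the compounds with values here, the only measured step that touches this part of the molecule, a step that the two limits leave unreadable from compound 1 to compound 2, is unreadable, so it offers no direction to expect, neither stronger nor weaker. Both values shown sit at the limit, and nothing in the numbers hints that compound 3 would move away from it. Compound 3 is therefore expected to give about 50000 nM in this assay, with a range from 15000 nM to 200000 nM. This expectation amounts to the step of a number no higher from compound 2 to compound 3 (the limit leaves the size open), which is most likely to appear as a limit once more.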

Compound 3, half-maximal inhibitory concentration: > 50000 nM
Compound 3 ended at the assay's limit (the forecaster's own chance of this, stated with the estimate: 80%); the middle value sits exactly at the limit.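

In this assay, going by these compounds alone, no step among compound 1, compound 2 and compound 3 can be read, because all three values are limits of the assay and not numbers: the limit of > 50000 nM in this assay, at which 3 of the 3 values shown sit. The compounds shown leave open whether any group at this place on the shared core gives a measurable inhibition, and how these three would rank against each other.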